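The compounds below may be only part of what the source reports. "The series", "measured", "known", "first", "only" and "open" are said of these compounds alone.

Compound 3 `COc1ccc(Cc2cnc(CCc3ccc(-c4ccccc4C(=O)O)cc3)[nH]2)cc1` stands highest of the three numbers in an in vitro functional assay on cells for agonist activity at Bombesin receptor subtype-3 (Mus musculus), read by luminescence and calcium flux (a higher number here means that more compound is needed for the effect, a lower number that less compound is needed), at 513 nM. Compound 1 `O=C(O)c1ccccc1-c1ccc(CCc2ncc(CC3CCCC3)[nH]2)cc1` gives 7.9 nM, and compound 2 `COc1cccc(Cc2cnc(CCc3ccc(-c4ccccc4C(=O)O)cc3)[nH]2)c1` gives 79 nM. The step of a 65-fold higher number from compound 1 to compound 3 (1.81 log units; beyond the scatter) is the largest in the set, a 10-fold higher number from compound 1 to compound 2 (1.00 log units; beyond the scatter) is modest, and a 6.5-fold higher number from compound 2 to compound 3 (0.81 log units; beyond the scatter) shows that the two methoxyphenyl groups differ beyond the scatter in this place.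

Compound 4 `O=C(O)c1ccccc1-c1ccc(CCc2ncc(Cc3ccccc3F)[nH]2)cc1` carries 2-fluorophenyl in place of 4-methoxyphenyl on a saturated chain carbon bound to an aromatic carbon. Going by the values given here, no measured step places a fluorophenyl here; the closest bearing is a 6.5-fold higher number from compound 2 to compound 3 (0.81 log units; beyond the scatter), which shows the number is sensitive to which substituted phenyl occupies this position. A downward step of roughly a 4.3-fold lower number from compound 3 to compound 4 (0.63 log units; beyond the scatter) is expected, beyond the scatter but uncertain. Compound 4 is estimated at 120 nM, with a range of 30 nM to 500 nM.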

Compound 4, half-maximal effective concentration: 9.5 nM
Beside the measured number, compound 4's estimate is 13-fold (1.10 log units) above it; the whole stated range lies above it.
By their numbers in this assay, from the lowest: compounds 1 and 4 (each within the scatter of the next); then compound 2; then compound 3.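

Of the aromatic groups shown at this position, only 2-fluorophenyl stays level with cyclopentyl: a 1.2-fold higher number from compound 1 to compound 4 (0.08 log units; within the scatter). It also departs clearly from both methoxyphenyl groups, with a 54-fold lower number from compound 3 to compound 4 (1.73 log units; beyond the scatter) and an 8.3-fold lower number from compound 2 to compound 4 (0.92 log units; beyond the scatter), so compounds 2 and 3 do not show a penalty shared by every substituted phenyl here. Nothing available explains these differences.

Open, going by these compounds, is whether the fluorine or the loss of methoxy governs this result. Unsubstituted phenyl, a chlorophenyl or an aminophenyl at this position would help separate the two.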